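This account rests on a few compounds, and the source may have more. Where it says the series, first, only, none or still open, it means among the compounds named here.

Measured in a functional assay on MDA-MB-231 cells (Homo sapiens) for antiproliferative activity, read by MTT assay; on this read-out higher numbers stand for weaker inhibition and lower numbers for stronger inhibition:
- compound 1 `CCCC/C=C/CCCCCCCCCC1(O)CC(=O)C2=C(O)C(C)C(O)C(C)=C2O1`: 6790 nM
- compound 2 `CCCC/C=C\CCCCCCCCCc1cc(=O)c2c(O)c(C)c(O)c(C)c2o1`: > 87000 nM (a limit of the assay, not a number)

In this assay, among the compounds with values here, compound 1 gives 6790 nM, the only true number so far, which makes it the single firm reference point. Compound 3 `CCCCCCCCCCCCCCCC1(O)CC(=O)C2=C(O)C(C)C(O)C(C)=C2O1` has not been measured yet. It departs from compound 1 in one place only: hexyl in place of hex-1-en-1-yl on a saturated chain carbon, nine bonds along the chain from a saturated ring carbon. The double bond in the chain is lost, while the rest of the molecule stays the same. Within the data shown here, no measured pair shows what this kind of change does. In this assay the expectation is therefore a step no larger than the usual scatter, with no favoured direction, starting from the 6790 nM of compound 1. The estimated change is a 1.0-fold higher number from compound 1 to compound 3 (0.01 log units; within the scatter). For compound 3 the estimated value is 7000 nM, with an expected range of 3000 nM to 18000 nM.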

Compound 3, half-maximal inhibitory concentration: 16100 nM
Compound 3: the middle estimate sits 2.3-fold (0.36 log units) below what was measured; the measured number falls inside the stated range.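

Within the data shown here, this is the first pair in this assay that differs in one place only, and it shows that the double bond in the chain is not a neutral feature: hexyl in place of hex-1-en-1-yl gives weaker inhibition (a 2.4-fold higher number from compound 1 to compound 3 (0.37 log units; beyond the scatter)). The step is modest, but it shows that a change nine bonds along the chain from a saturated ring carbon can still be read in this assay while the rest of the molecule stays the same. Nothing shown accounts for this step.

Still open, as far as these compounds go, is whether a shorter chain, a longer chain or a carboxylic acid on the chain would shift the number further on the core of compound 1. Compound 2 cannot settle this: it gives > 87000 nM, which is a limit of the assay and not a number.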